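Bradykinin B1 antagonist series: ring-opened amine variant of compound 3

This account rests on a few compounds, and the source may have more. Where it says the series, first, only, none or still open, it means among the compounds named here.

Measured compounds:
- compound 1 `COc1ccc(S(=O)(=O)N(C)CCOCC(=O)N(C)Cc2ccc(C3=NCCN3)cc2)c(C)c1`: 8.6
- compound 2 `COc1cc(C)c(S(=O)(=O)N(C)CCOCC(=O)N2CCN(CCN(C)C)CC2)c(C)c1`: 7.4
- compound 3 `COc1cc(C)c(S(=O)(=O)N(C)CCOCC(=O)N2CCC(C3CCN(C)CC3)CC2)c(C)c1`: 9

All three were run in a functional assay on Umbilical vein for antagonist activity at B1 bradykinin receptor (Homo sapiens), using Schild analysis, with a stated time of 30 min; a higher number here means a more potent compound, by a factor of ten per unit of this negative logarithm, a lower number a less potent compound. Compound 3 gives the highest number of the three, with 9. The nearest value is that of compound 1, lower by a margin beyond the scatter; compound 2 lies furthest, well beyond the scatter. Compound 3 can therefore be called the most potent of the measured set.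

Compound 4 `COc1cc(C)c(S(=O)(=O)N(C)CCOCC(=O)N2CCC(C(C)(C)CN(C)C)CC2)c(C)c1` is not yet measured. It keeps the core of compound 3 and differs in one place: 1-((dimethylamino)methyl)-1-methylethyl in place of 1-methylpiperidin-4-yl on a saturated ring carbon. Among the compounds with values here, nothing among the measured compounds probes this ring-to-chain exchange directly, so no measured step tells its size. Compound 2, which also carries an acyclic dimethylamino chain, sits far below compound 3, but its amide part differs in more than one place.

For compound 4, a moderate loss is expected, with the estimated step being a number 0.50 log units lower from compound 3 to compound 4 (beyond the scatter). Compound 4 is estimated at 8.5, within a range of 7.8 to 9.2.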

Compound 4, negative logarithm of the antagonist equilibrium constant: 7.5
Compound 4: middle estimate off by 1.00 log units, on the high side; the whole stated range lies above it.
By their numbers in this assay, from the lowest: compounds 2 and 4 (each within the scatter of the next); then compound 1; then compound 3.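

In this assay, within the data shown here, putting 1-((dimethylamino)methyl)-1-methylethyl in place of 1-methylpiperidin-4-yl on the saturated ring carbon gives a number 1.50 log units lower from compound 3 to compound 4 (beyond the scatter), the first direct reading of a change at this position. Both groups have the same counts of heavy atoms, donors and acceptors, and the entering group has no ring, so this position responds strongly to a change that leaves those counts the same. Nothing shown accounts for the size of this step.

As far as these compounds go, it remains open whether the step follows from the loss of the ring itself or from this particular chain with its two methyl groups. A straight 3-(dimethylamino)propyl chain, or a piperidin-4-yl group with a hydrogen in place of the methyl on nitrogen, would test this at the same ring carbon.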